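The compounds below may be only part of what the source reports. "The series", "measured", "known", "first", "only" and "open" are said of these compounds alone.

Compound 1 `CC(NC(=O)c1ccc([N+](=O)[O-])o1)c1ccccc1` in an ADME assay on Vero cells (Chlorocebus sabaeus) for cytotoxicity, read by MTT assay, with a stated time of 48 h (on this read-out lower numbers stand for higher toxicity in this test and higher numbers for lower toxicity in this test), gives 24000 nM. Compound 2 `O=C(Nc1ccc2ccccc2c1)c1ccc([N+](=O)[O-])o1` in this assay gives only a limit of the assay, > 150000 nM. Compound 3 `CC(C)(NC(=O)c1ccc([N+](=O)[O-])o1)c1ccc(Cl)cc1` in this assay gives 81000 nM.

Among the two values that are numbers, compound 3 stands highest, and its gap to compound 1 lies beyond the scatter, so compound 3 reads as the less toxic of the two in this assay. The third value shown is not a number but a limit; (the limit of > 150000 nM in this assay, at which 1 of the 3 values shown sits).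

Compound 4 `COc1ccc(OCc2ccc(C(C)(C)NC(=O)c3ccc([N+](=O)[O-])o3)cc2)cc1` has not yet been measured in this assay. Set against compound 3, the change is (4-methoxyphenoxy)methyl in place of chloro on an aromatic carbon. No step between measured compounds matches this change, so nothing in the shown numbers tells how far the value moves. The nitrofuran amide part that the three measured compounds share is kept unchanged.

On that basis compound 3 to compound 4 is expected to be a step of modest size, a 1.0-fold lower number from compound 3 to compound 4 (0.01 log units; within the scatter), not clearly beyond the scatter in either direction. For compound 4 the estimate in this assay is 80000 nM, with a range from 25000 nM to 200000 nM, and some chance that only a limit is reported.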

Compound 4, half-maximal cytotoxic concentration: > 120000 nM
Compound 4 was reported as a limit; the forecaster's own chance of this, stated with the estimate: 30%; middle value at least 1.5-fold (0.17 log units) away from the limit.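

At the aromatic carbon para to a large group, compound 3 carries chloro, and compound 4 gives the first view of a far larger group there: in this assay, (4-methoxyphenoxy)methyl in place of chloro gives an at least 1.4-fold higher number from compound 3 to compound 4 (0.17 log units; that floor lies within the scatter). The entering group, with its six-membered aromatic ring of carbon only and its two hydrogen-bond acceptors, thus brings no sign of a lower number, which would have stood for higher toxicity in this test. Compound 4 is reported only as a limit, so the true size of the step stays unknown, and its floor does not clear the usual variation between repeated measurements: the limit of > 120000 nM in this assay, at which 1 of the 4 values shown sits.

The entering group changes as a whole, so the compounds shown cannot tell whether the outcome belongs to its outer aromatic ring, its methoxy or its ether oxygen. They also leave open how the number would respond at this place to an amine, a carboxylic acid or a simple longer alkyl chain.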